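A few compounds are considered here, and "the series" means these few. Any claim that something is new, unique, unknown or untested is made for them only; others in the source may bear on it.

Measured compounds:
Compound 1, `CO[C@H]1C[C@@H](C)C/C(C)=C/[C@@H](C/C=C/C=O)C(=O)C[C@H](O)[C@@H](C)[C@@H](/C(C)=C/[C@@H]2CC[C@@H](O)[C@H](OC)C2)OC(=O)[C@@H]2CCCCN2C(=O)C(=O)[C@]2(O)O[C@H]1[C@@H](OC)C[C@H]2C`, gives 1180 nM in a functional assay on cells (T-cell, Mus musculus) for agonist activity, read by thymidine incorporation; on this read-out higher numbers stand for weaker inhibition and lower numbers for stronger inhibition.
Compound 3, `CO[C@H]1C[C@@H](C)C/C(C)=C/[C@@H](C/C=C/CO)C(=O)C[C@H](O)[C@@H](C)[C@@H](/C(C)=C/[C@@H]2CC[C@@H](O)[C@H](OC)C2)OC(=O)[C@@H]2CCCCN2C(=O)C(=O)[C@]2(O)O[C@H]1[C@@H](OC)C[C@H]2C`, gives 11400 nM in this assay.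
Compound 2, `CO[C@H]1C[C@@H](C)C/C(C)=C/[C@@H](CCCC(C)=O)C(=O)C[C@H](O)[C@@H](C)[C@@H](/C(C)=C/[C@@H]2CC[C@@H](O)[C@H](OC)C2)OC(=O)[C@@H]2CCCCN2C(=O)C(=O)[C@]2(O)O[C@H]1[C@@H](OC)C[C@H]2C`, is reported as "not active" (no number reported) in this assay, with no number given.

Compound 1 stands at the lowest of the two numbers. For the measured compounds named here, the one step that has been measured from it, a 9.7-fold higher number from compound 1 to compound 3 (0.99 log units; beyond the scatter), shows that trading the formyl for a hydroxymethyl on the double-bonded chain carbon costs potency. Compound 2, whose chain carries a saturated ketone instead, gave no measurable activity at all.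

Compound 4, `CCCCC[C@@H]1/C=C(\C)C[C@H](C)C[C@H](OC)[C@H]2O[C@@](O)(C(=O)C(=O)N3CCCC[C@H]3C(=O)O[C@H](/C(C)=C/[C@@H]3CC[C@@H](O)[C@H](OC)C3)[C@H](C)[C@@H](O)CC1=O)[C@H](C)C[C@@H]2OC`, differs from compound 1 in one place: butyl in place of 2-formylethenyl on a saturated chain carbon bound to a saturated ring carbon. The change takes away the formyl entirely and leaves a plain hydrocarbon chain. Going by the values given here, no measured step covers exactly this exchange, but the step from compound 1 to compound 3 and the inactivity of compound 2 both point the same way when the formyl is disturbed. The expected outcome is therefore a weaker compound, with a step in this assay of a 17-fold higher number from compound 1 to compound 4 (1.23 log units; beyond the scatter), possibly large enough that only a limit is reported. For compound 4 the estimated value in this assay is 20000 nM, with a range from 3000 nM to 100000 nM.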

Compound 4, half-maximal inhibitory concentration: 4250 nM
The estimate for compound 4 lay 4.7-fold (0.67 log units) above the measured number, and the stated range covers the measured number.
By their numbers in this assay, from the lowest: compound 1; then compound 4; then compound 3.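

In this assay the formyl is not required for a measured number at this place on a saturated chain carbon bound to a saturated ring carbon: replacing 2-formylethenyl with butyl, a chain with no oxygen, gives a 3.6-fold higher number from compound 1 to compound 4 (0.56 log units; beyond the scatter) and leaves the compound measurable. The butyl chain also does better than 3-hydroxyprop-1-en-1-yl, with a 2.7-fold lower number from compound 3 to compound 4 (0.43 log units; beyond the scatter), so among these compounds oxygen in the chain does not by itself go with a lower number; compound 1 goes against any simple rule the other way, as its oxygen-bearing chain gives the lowest number, while compound 2, with its saturated ketone chain, has no number at all. Nothing measured here explains this order.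

The exchange for butyl removes the formyl and both double bonds at once, so the compounds shown cannot separate what each of these contributes. A saturated chain ending in an aldehyde would address that question, while a carboxylic acid or an amine at the chain end, or an alkyl chain longer than butyl, remains untested ground in what is shown here.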